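Solubility of two pyrimidinone analogs and one untested relative

The compounds below may be only part of what the source reports. "The series", "measured", "known", "first", "only" and "open" are said of these compounds alone.

Measured compounds:
compound 1, `Cc1cc(C)n(-c2nc(C)c(-c3ccccc3)c(=O)[nH]2)n1`, 190000 nM
compound 2, `Cc1cc(C2CC2)n(-c2nc(C(F)(F)F)cc(=O)[nH]2)n1`, 160000 nM

Of the compounds shown here, two have been measured in a physicochemical assay for solubility, at pH 7.4; on this read-out higher numbers stand for higher solubility and lower numbers for lower solubility. Compound 1 is `Cc1cc(C)n(-c2nc(C)c(-c3ccccc3)c(=O)[nH]2)n1` and in this assay compound 1 gives 190000 nM. Compound 2 is `Cc1cc(C2CC2)n(-c2nc(C(F)(F)F)cc(=O)[nH]2)n1` and in this assay compound 2 gives 160000 nM. Compound 2 holds the lower of the two numbers, but the gap to compound 1 is within the scatter of repeated measurements, so the two values cannot be told apart.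

Compound 3, `Cc1cc(Nc2ccc(F)cc2)n(-c2nc(C(F)(F)F)cc(=O)[nH]2)n1`, has not yet been measured. It differs from compound 2 in one place: (4-fluorophenyl)amino in place of cyclopropyl on an aromatic carbon. Within the data shown here, no step between measured compounds bears on this change, so the expectation rests on the structures alone. For compound 3 a decrease in solubility relative to compound 2 is expected, and the estimated step of a 5.3-fold lower number from compound 2 to compound 3 (0.73 log units; beyond the scatter) is judged to lie beyond the scatter. In this assay compound 3 is expected to give about 30000 nM, with a range from 8000 nM to 100000 nM.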

Compound 3, solubility: 15000 nM
Compound 3: the middle estimate sits 2.0-fold (0.30 log units) above what was measured; the measured number falls inside the stated range.
By their numbers in this assay, from the lowest: compound 3; then compounds 2 and 1 (each within the scatter of the next).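

Among these compounds, compound 3 gives the first sign that the group on this aromatic carbon of the five-membered aromatic ring can matter in this assay: with (4-fluorophenyl)amino in place of cyclopropyl, the read-out shows an 11-fold lower number from compound 2 to compound 3 (1.03 log units; beyond the scatter), a large step beyond the scatter. Among the compounds shown here, compounds 1 and 2 stood within the scatter of each other and differ in more than one place, so they offered no step from which to read this position. The step belongs to the exchange as a whole, a three-membered non-aromatic ring of carbon only leaving and a six-membered aromatic ring with its nitrogen link and fluorine entering, and nothing given here bears on why the number moves this far.

The compounds shown leave open which part of the entering group carries the step, since a plain phenylamino group, a simple amine or a methoxy group on the same carbon would separate the aromatic ring, the nitrogen link and the fluorine. They also leave open whether the same exchange would give a step of similar size on the core of compound 1.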